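The source may hold more compounds than are shown below. What is called first, only, known or untested is meant among the compounds shown, and "the series" means these compounds.

Measured in an ADME assay on SH-SY5Y cells (Homo sapiens) for cytotoxicity, read by MTT assay, with a stated time of 72 h; on this read-out higher numbers stand for lower toxicity in this test and lower numbers for higher toxicity in this test:
- compound 1 `c1coc(-c2cn3ccccc3n2)c1`: > 100000 nM, a limit
- compound 2 `c1ccc(-c2cn3cc(-c4ccco4)ccc3n2)cc1`: > 100000 nM, a limit
- compound 3 `COc1ccc(-c2cn3cc(-c4ccco4)ccc3n2)cc1OC`: 30000 nM

Compound 2 has no exact number, only a limit: it sits at the limit of > 100000 nM in this assay, at which 2 of the 3 values shown sit. Compound 4 `c1coc(-c2ccc3nc(-c4ccco4)cn3c2)c1` differs from compound 2 in one place, with furan-2-yl in place of phenyl on an aromatic carbon. Within the data shown here, no measured pair shows this change alone. Compound 1 also carries furan-2-yl on that ring, and its > 100000 nM is again a limit. The expected step in this assay, a number no higher from compound 2 to compound 4 (the limit leaves the size open), is none beyond the usual scatter. Compound 4 is expected near 100000 nM, with an estimated range of 40000 nM to 200000 nM.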

Compound 4, half-maximal cytotoxic concentration: 3000 nM
Beside the measured number, compound 4's estimate is 33-fold (1.52 log units) above it, outside the stated range (below it).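

In this assay, furan-2-yl in place of phenyl on an aromatic carbon of the five-membered ring gives an at least 33-fold lower number from compound 2 to compound 4 (1.52 log units; beyond the scatter), so this position clearly affects toxicity in this test. Adding furan-2-yl in place of hydrogen at the other site gives an at least 33-fold lower number from compound 1 to compound 4 (1.52 log units; beyond the scatter), so among these compounds, the clear rise in toxicity appears only with both furan-2-yl groups present. Both steps are minimum sizes because their starting values are limits: the limit of > 100000 nM in this assay, at which 2 of the 4 values shown sit.

The compounds shown leave open whether the effect is specific to furan-2-yl or would also appear with another ring, such as thiophene, or with an amine at this position.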